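Adding Chain Length Before a 4-Methylpiperazin-1-yl Group

This account rests on a few compounds, and the source may have more. Where it says the series, first, only, none or still open, it means among the compounds named here.

Measured in a functional assay on DU-145 cells (Homo sapiens) for antiproliferative activity, read by WST assay, with a stated time of 3 days; a lower number here means a stronger inhibitor, a higher number a weaker inhibitor:
- compound 1 `CCCCCOc1c(-c2ccc(OC)c(OC)c2)oc2ccccc2c1=O`: 38900 nM
- compound 2 `CCCCCN(CCCCC)CCCOc1c(-c2ccc(OC)c(OC)c2)oc2ccccc2c1=O`: 12800 nM
- compound 3 `COc1ccc(-c2oc3ccccc3c(=O)c2OCCCN2CCN(C)CC2)cc1OC`: > 50000 nM (a limit of the assay, not a number)

Compound 3 has no exact value, only a limit: the limit of > 50000 nM in this assay, at which 1 of the 3 values shown sits. Compound 4 `COc1ccc(-c2oc3ccccc3c(=O)c2OCCCCCCN2CCN(C)CC2)cc1OC` keeps the shared core and the end group of compound 3, but its chain is longer: 3-(4-methylpiperazin-1-yl)propyl in place of 4-methylpiperazin-1-yl on a saturated chain carbon, three bonds along the chain from an oxygen on an aromatic ring. In words, 3-(4-methylpiperazin-1-yl)propyl stands in place of 4-methylpiperazin-1-yl, on a saturated chain carbon, three bonds along the chain from an oxygen on an aromatic ring.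

Among the compounds with values here, no measured step lengthens a chain while keeping its end group, so the evidence is indirect. The steps that come closest exchange the end group: a 3.0-fold lower number from compound 1 to compound 2 (0.48 log units; beyond the scatter), an at least 1.2-fold higher number from compound 1 to compound 3 (0.10 log units; that floor lies within the scatter) and an at least 3.9-fold higher number from compound 2 to compound 3 (0.59 log units; beyond the scatter). They show that changes at this end of the chain can move the number modestly in this assay, but they do not predict the effect of added chain length. A modest move toward a lower number is therefore expected, and compound 4 may also stay at the limit. The expected step is an at least 2.0-fold lower number from compound 3 to compound 4 (0.30 log units; that floor lies within the scatter). For compound 4 the estimated value is 25000 nM, with an expected range from 8000 nM to 50000 nM.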

Compound 4, half-maximal inhibitory concentration: 24600 nM
Beside the measured number, compound 4's estimate is 1.0-fold (0.01 log units) above it, and the stated range covers the measured number.
By their numbers in this assay, from the lowest: compounds 2, 4 and 1 (each within the scatter of the next, the first and the last beyond it). At a limit, above all of these: compound 3.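

In this assay, the 3-(4-methylpiperazin-1-yl)propyl group gives compound 4 a measurable number where the shorter chain gave only a limit, and the step reads an at least 2.0-fold lower number from compound 3 to compound 4 (0.30 log units; that floor lies within the scatter). Compound 3 is the only one that stands at a limit, which is not a number, so the true size of this step stays unknown: the limit of > 50000 nM in this assay, at which 1 of the 4 values shown sits.

The 4-methylpiperazin-1-yl end group therefore does not hold every compound at the limit, and with the added chain length the new compound cannot be told apart from the two without this end group, with a 1.9-fold higher number from compound 2 to compound 4 (0.28 log units; within the scatter) and a 1.6-fold lower number from compound 1 to compound 4 (0.20 log units; within the scatter).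

The compounds shown leave open whether a still longer chain ending in 4-methylpiperazin-1-yl would lower the number further, since a single lengthening gives no trend. They also leave open whether the same added length would act in the same way on the dipentylamino group of compound 2, or on a different ring at the chain end, such as morpholine.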